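Dichlorophenyl isomers: from compound 3 to compound 4

This account rests on a few compounds, and the source may have more. Where it says the series, first, only, none or still open, it means among the compounds named here.

- compound 1 `COc1ccc(/C=C2\CCC/C(=C\c3ccc(Br)cc3)C2=O)cc1OC` gives 4300 nM
- compound 2 `COc1ccc(/C=C2\CCC/C(=C\c3ccc(O)cc3)C2=O)cc1OC` gives 16800 nM
- compound 3 `COc1ccc(/C=C2\CCC/C(=C\c3ccc(Cl)cc3Cl)C2=O)cc1OC` gives 10500 nM

All three values come from a functional assay on HT-1080 cells (Homo sapiens) for cytotoxicity, read by MTT assay, with a stated time of 72 h (a lower number here means a stronger inhibitor, a higher number a weaker inhibitor), and sit within a narrow spread. Compound 3 belongs with the higher numbers: the step of a 2.4-fold higher number from compound 1 to compound 3 (0.39 log units; beyond the scatter) sets it apart from the lowest value, whereas a 1.6-fold lower number from compound 2 to compound 3 (0.20 log units; within the scatter) does not set it apart from the other high value.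

The next compound is compound 4 `COc1ccc(/C=C2\CCC/C(=C\c3ccc(Cl)c(Cl)c3)C2=O)cc1OC` and its only difference is 3,4-dichlorophenyl in place of 2,4-dichlorophenyl on a double-bonded chain carbon bound to a double-bonded ring carbon in the otherwise shared core. Among the measured compounds shown here, no measured step compares two dichlorophenyl isomers, so the evidence is indirect. Two changes at this same place on the core bear on it: a 2.4-fold higher number from compound 1 to compound 3 (0.39 log units; beyond the scatter) and a 3.9-fold higher number from compound 1 to compound 2 (0.59 log units; beyond the scatter) are both modest, so a large step in this assay is not expected. For the measured compounds named here, the two halogenated compounds measured so far stay apart by only that first modest step, and compound 1 at 4300 nM gives a weak lean toward a lower number.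

The expected change is a 1.4-fold lower number from compound 3 to compound 4 (0.15 log units; within the scatter) and it is not expected to pass the scatter. The estimate for compound 4 is 7500 nM with an expected range of 3000 nM to 18000 nM at this stage.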

Compound 4, half-maximal inhibitory concentration: 3100 nM
For compound 4 the middle estimate is 2.4-fold (0.38 log units) above the measured one; the measured number falls inside the stated range.
By their numbers in this assay, from the lowest: compounds 4 and 1 (each within the scatter of the next); then compounds 3 and 2 (each within the scatter of the next).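

In this assay, the arrangement of the two chlorines alone is enough to move the number at this place on the shared core: with the same atoms on both sides of the change, 3,4-dichlorophenyl in place of 2,4-dichlorophenyl gives a 3.4-fold lower number from compound 3 to compound 4 (0.53 log units; beyond the scatter), a step beyond the scatter that the earlier single-group changes could not isolate. The series now falls into two groups, since 3,4-dichlorophenyl stands clear of 4-hydroxyphenyl, with a 5.4-fold lower number from compound 2 to compound 4 (0.73 log units; beyond the scatter), but not of 4-bromophenyl, with a 1.4-fold lower number from compound 1 to compound 4 (0.14 log units; within the scatter), so that compound 4 and compound 1 form the low pair, while compound 3 shows that halogen on this group does not by itself place a compound there. Nothing available here accounts for the difference between the two isomers.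

Still open, on these data alone, is whether a single chlorine, as in 3-chlorophenyl or 4-chlorophenyl, would stay with compound 4 and compound 1, and whether the second chlorine of compound 4 contributes anything. As far as these compounds go, it is equally open how an amine or a carboxylic acid on this group would read in this assay, and whether the split between the two pairs holds in other cell lines.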